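The compounds below may be only part of what the source reports. "The series", "measured", "known", "first", "only" and "open" are said of these compounds alone.

Compound 1 `CN1CCN(c2nc(-c3ccc(Cl)c(Cl)c3)nc3[nH]cnc23)CC1` — > 80%
Compound 2 `Clc1ccc(-c2nc(N3CCCCC3)c3nc[nH]c3n2)cc1Cl` — > 80%
Compound 3 `CN1CCN(c2nc(-c3ccc(Cl)c(Cl)c3)nc3c2ncn3C)CC1` — 35.3%

In an assay on cells for displacement of a labelled ligand from adenosine receptor A3 (Homo sapiens), read by scintillation counting and radioligand binding, with a stated time of 180 min, tested at 10 uM (on this read-out higher numbers stand for more inhibition at the one concentration tested (going by the name of the read-out) and lower numbers for less inhibition), compound 1 gives only a limit, > 80%, not a number. That is the limit of > 80% in this assay, at which 2 of the 3 values shown sit. Compound 2 likewise gives a limit, > 80%. The step that the two limits leave unreadable from compound 1 to compound 2 therefore cannot be sized. Compound 3 gives a number, 35.3%, and the step of a number at least 44.7 percentage points lower from compound 1 to compound 3 (beyond the scatter) is a large loss. Compound 4 `CN1CCN(c2nc(-c3ccc(Cl)c(C(F)(F)F)c3)nc3[nH]cnc23)CC1` differs from compound 1 by trifluoromethyl in place of chloro on an aromatic carbon. Within the data shown here, neither measured step touches that part of the molecule, one altering the amine and the other the core nitrogen, so no measured step bears directly on this change. A step within the scatter is expected, a number at least 5 percentage points lower from compound 1 to compound 4 (that floor lies within the scatter). Compound 4 is estimated at 75%, between 45% and 95%.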

Compound 4, a percentage reported as inhibition, at one concentration (the size of the read-out at that concentration, not a potency): > 80%
Compound 4: a limit, no number; the forecaster's own chance of this, stated with the estimate: 45%; middle value at least 5 percentage points from the limit.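

Compound 1 and compound 4 both give only a limit in this assay, so no step between them can be read: the limit of > 80% in this assay, at which 3 of the 4 values shown sit.

From the compounds shown here alone, whether trifluoromethyl in place of chloro changes inhibition at all, and in which direction, stays open.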